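This account rests on a few compounds, and the source may have more. Where it says the series, first, only, none or still open, it means among the compounds named here.

Compounds measured so far:
- compound 1 `Cc1ccccc1OCC(O)CNCC(=O)Nc1ccc(C2=NNC(=O)CC2C)cc1`: 2.7 umol/kg
- compound 2 `COc1ccccc1OCC(O)CNCC(=O)Nc1ccc(C2=NNC(=O)CC2)cc1`: 4.6 umol/kg
- compound 3 `COc1ccccc1OCC(O)CNCC(=O)Nc1ccc(C2=NNC(=O)CC2C)cc1`: 3 umol/kg

In a functional assay on the whole organism with Rattus norvegicus as the target (a higher number here means that more compound is needed for the effect, a lower number that less compound is needed), compound 3 gives 3 umol/kg, which lies within the scatter of both other compounds, so the three values cannot be ranked. Compound 4 `CC1CC(=O)NN=C1c1ccc(NC(=O)CNCC(O)COc2ccccc2C#N)cc1` differs from compound 3 by one change, (cyano in place of methoxy on an aromatic carbon). The nearest evidence comes from the same kind of aromatic carbon: a 1.1-fold higher number from compound 1 to compound 3 (0.05 log units; within the scatter), a replacement of methyl by methoxy that stays within the scatter. The other measured step, a 1.5-fold lower number from compound 2 to compound 3 (0.19 log units; within the scatter), concerns a saturated ring carbon and also stays within the scatter, so it bears on the new change only indirectly. Going by the values given here, no compound with a cyano group has been measured, so the data give no direction for this change and leave the uncertainty wide. The expected result is no change at the digits printed from compound 3 to compound 4 (within the scatter), with no shift beyond the scatter anticipated. Compound 4 is estimated at 3 umol/kg, with an expected range from 1 umol/kg to 9 umol/kg.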

Compound 4, dose for half-maximal effect: 0.9 umol/kg
For compound 4 the middle estimate is 3.3-fold (0.52 log units) above the measured one, outside the stated range (below it).
By their numbers in this assay, from the lowest: compound 4; then compounds 1, 3 and 2 (each within the scatter of the next).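

Going by these compounds alone, at this aromatic carbon, ortho to a large group, the swap between methyl and methoxy had left this assay within the scatter, and cyano is the first group there to move the number beyond it, with a 3.3-fold lower number from compound 3 to compound 4 (0.52 log units; beyond the scatter) and a 3.0-fold lower number from compound 1 to compound 4 (0.48 log units; beyond the scatter). Both steps run the same way, so on this core less compound is needed with cyano than with either methoxy or methyl at this position. Nothing available here accounts for this difference between the nitrile and the other two groups.

On these data alone, whether the shift is particular to the nitrile, or would also come with another group on this carbon, such as chlorine, an amine or a carboxylic acid, stays open. As far as these compounds go, it is also open whether cyano would give a similar step on compound 2, which has hydrogen in place of the methyl on the saturated ring carbon.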